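This account rests on a few compounds, and the source may have more. Where it says the series, first, only, none or still open, it means among the compounds named here.

Values in a functional assay on SW-620 cells (Homo sapiens) (a higher number here means a weaker inhibitor of growth, a lower number a stronger inhibitor of growth), so far:
- compound 1 `N#Cc1ccc(/C=C/S(=O)(=O)Cc2ccc(Nc3ncnc4ccccc34)cc2)cc1` gives > 100000 nM (a limit of the assay, not a number)
- compound 2 `O=S(=O)(/C=C/c1ccc(Cl)c(Cl)c1)Cc1ccc(Nc2ncnc3ccccc23)cc1` gives 41000 nM
- compound 3 `O=S(=O)(/C=C/c1ccc(Cl)cc1)Cc1ccc(Nc2ncnc3ccccc23)cc1` gives 77000 nM

Compound 3 and compound 2 sit within the scatter of each other (a 1.9-fold higher number from compound 2 to compound 3 (0.27 log units; within the scatter)). Compound 4 `O=S(=O)(/C=C/c1ccc(F)cc1F)Cc1ccc(Nc2ncnc3ccccc23)cc1` carries 2,4-difluorophenyl in place of 4-chlorophenyl on a double-bonded chain carbon bound to a double-bonded chain carbon. For the measured compounds named here, no measured step brings in fluorine. The steps from the limit (an at least 2.4-fold lower number from compound 1 to compound 2 (0.38 log units; beyond the scatter); an at least 1.2-fold lower number from compound 1 to compound 3 (0.11 log units; that floor lies within the scatter)) give bounds only. Going by the values given here, the one step between two numbers stayed within the scatter, so no step beyond the scatter is expected in this assay here. The expected step is small (a 1.1-fold lower number from compound 3 to compound 4 (0.04 log units; within the scatter)). Compound 4 is estimated at 70000 nM with an expected range of 30000 nM to 100000 nM (a limit remains possible).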

Compound 4, concentration for 50% growth inhibition: 86000 nM
The estimate for compound 4 lay 1.2-fold (0.09 log units) below the measured number; low and high end bracket the measured number.
By their numbers in this assay, from the lowest: compounds 2, 3 and 4 (each within the scatter of the next, the first and the last beyond it). At a limit, above all of these: compound 1.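

In this assay, 2,4-difluorophenyl in place of 4-chlorophenyl brings in fluorine, and the step stays within the scatter (a 1.1-fold higher number from compound 3 to compound 4 (0.05 log units; within the scatter)). Against 3,4-dichlorophenyl, the same group gives the first step between two numbers that lies beyond the scatter, though it is only modest (a 2.1-fold higher number from compound 2 to compound 4 (0.32 log units; beyond the scatter)). Compound 1 stands at a limit of the assay: the limit of > 100000 nM in this assay, at which 1 of the 4 values shown sits. The remaining step therefore gives a bound only (an at least 1.1-fold lower number from compound 1 to compound 4 (0.06 log units; that floor lies within the scatter)).

On these data alone, what an amine or a carboxylic acid on this aromatic ring would do remains open. Also open, as far as these compounds go, is whether any group here moves the number well under that of compound 2, 41000 nM.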